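Swapping (3-methylphenyl)amino for (piperidin-1-yl)methyl on a carbonyl carbon

The source may report more compounds than this note shows. Statements on the series, on what has been measured and on what is new or still open speak of the compounds shown alone.

Measured in a functional assay (strain AB) with Danio rerio as the target, read by microscopy, with a stated time of 1 h; on this read-out lower numbers stand for an effect already at smaller amounts and higher numbers for an effect only at larger amounts of compound:
- Compound 1 `CCN1CCc2c(sc(NC=O)c2C(N)=O)C1`: > 25000 nM, a limit of the assay and not a number
- Compound 2 `CCN1CCc2c(sc(NC(=O)Nc3ccc(Cl)cc3)c2C(N)=O)C1`: 3120 nM
- Compound 3 `CCN1CCc2c(sc(NC(=O)Nc3cccc(C)c3)c2C(N)=O)C1`: 13000 nM

Of the two true numbers, compound 3 stands higher at 13000 nM, and the only other one belongs to compound 2 at 3120 nM. Compound 4 `CCN1CCc2c(sc(NC(=O)CN3CCCCC3)c2C(N)=O)C1` keeps the shared core, but (piperidin-1-yl)methyl takes the place of (3-methylphenyl)amino on a carbonyl carbon ((piperidin-1-yl)methyl in place of (3-methylphenyl)amino on a carbonyl carbon).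

Two measured steps change the same carbonyl carbon: an at least 8.0-fold lower number from compound 1 to compound 2 (0.90 log units; beyond the scatter) and an at least 1.9-fold lower number from compound 1 to compound 3 (0.28 log units; that floor lies within the scatter). A third, a 4.2-fold higher number from compound 2 to compound 3 (0.62 log units; beyond the scatter), shows that exchanging one group for another near this spot can shift the number beyond the scatter. For the measured compounds named here, no measured compound carries (piperidin-1-yl)methyl, so these steps give only a rough guide to the size of the change, and none gives its direction. With no direction to go on, no step beyond the scatter is expected in this assay, though the uncertainty is wide either way. The expected change is a 1.1-fold higher number from compound 3 to compound 4 (0.03 log units; within the scatter). Compound 4 may also return only a limit. For compound 4 the estimated value is 14000 nM, with an expected range from 4000 nM to 40000 nM.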

Compound 4, half-maximal effective concentration: > 25000 nM
Compound 4 ended at the assay's limit (the forecaster's own chance of this, stated with the estimate: 35%); middle value at least 1.7-fold (0.25 log units) away from the limit.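

In this assay, (piperidin-1-yl)methyl in place of (4-chlorophenyl)amino on the carbonyl carbon gives an at least 8.0-fold higher number from compound 2 to compound 4 (0.90 log units; beyond the scatter), so at this position not every added ring group keeps the effect seen with compound 2. Against the weaker partner, the change gives an at least 1.9-fold higher number from compound 3 to compound 4 (0.28 log units; that floor lies within the scatter), and this floor is too small to separate the two compounds. Compound 4 returns only a limit of the assay and not a number, and the step between compound 1 and compound 4 cannot be read, since both sit at the same limit: the limit of > 25000 nM in this assay, at which 2 of the 4 values shown sit.

The compounds shown leave open which part of the arylamino groups matters, as the aromatic ring and the hydrogen-bond donor leave together in the change to (piperidin-1-yl)methyl. A benzyl group on the same carbonyl carbon, which keeps an aromatic ring without the amino hydrogen, and a cyclohexylamino group, which keeps that hydrogen without an aromatic ring, would pull these two features apart.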